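The source may hold more compounds than are shown below. What is called first, only, known or untested is meant among the compounds shown, and "the series" means these compounds.

Compound 1 `CC(=O)OC/C1=C/C[C@](C)(CCC=C(C)C)/C=C/[C@@H](OC(=O)C=C(C)C)[C@](C)(O)/C=C/C1=O` is the starting point of this comparison. Going by the values given here, in a functional assay on HL-60 cells (Homo sapiens) for antiproliferative activity, read by MTT assay, with a stated time of 48 h (a lower number here means a stronger inhibitor, a higher number a weaker inhibitor), compound 1 gives 2950 nM, which is the larger of the two numbers in hand, though only nominally so: its sole neighbour is compound 2 `CC(C)=CCC[C@]1(C)/C=C/[C@@H](OC(=O)C=C(C)C)[C@](C)(O)/C=C/C(=O)/C(C[Si](C)(C)C(C)(C)C)=C\C1`, which in this assay gives 2770 nM, and the step of a 1.1-fold lower number from compound 1 to compound 2 (0.03 log units; within the scatter) lies within the scatter, so the two compounds stand level.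

Compound 3 `CC(C)=CCC[C@]1(C)/C=C/[C@@H](OC(=O)C=C(C)C)[C@](C)(O)/C=C/C(=O)/C(C(=O)N(C)C)=C\C1` has not yet been measured. It differs from compound 1 by dimethylcarbamoyl in place of acetoxymethyl on a double-bonded ring carbon. Among the compounds with values here, the one measured step that bears on this is a 1.1-fold lower number from compound 1 to compound 2 (0.03 log units; within the scatter), since it also swaps out the acetoxymethyl group at the same double-bonded ring carbon for a different group of no ring, and it left the number essentially where it was. Within the data shown here, with only that single step as a guide, and no measured compound carrying a dimethylcarbamoyl group, the expectation for compound 3 is a step of a 1.0-fold lower number from compound 1 to compound 3 (0.01 log units; within the scatter) that does not exceed the scatter. Compound 3 is therefore estimated at 2900 nM in this assay, within a range of 1300 nM to 6500 nM.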

Compound 3, half-maximal inhibitory concentration: 3340 nM
Compound 3: the middle estimate sits 1.2-fold (0.06 log units) below what was measured; the range from low to high includes it.
By their numbers in this assay, from the lowest: compounds 2, 1 and 3 (each within the scatter of the next).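

In this assay, dimethylcarbamoyl on the double-bonded ring carbon stands level with the acetoxymethyl group it replaces, a 1.1-fold higher number from compound 1 to compound 3 (0.05 log units; within the scatter), and with the silicon-bearing group of compound 2, a 1.2-fold higher number from compound 2 to compound 3 (0.08 log units; within the scatter). Compound 1 and compound 2 reach this ring carbon through a saturated chain carbon, whereas compound 3 reaches it through a carbonyl and brings in nitrogen, so among these three compounds neither the attachment nor the make-up of the group moves the number beyond the scatter. Nothing at hand explains why these three groups stand level.

On these data alone, all three groups here are ringless and carry no net charge, so it remains open whether a primary amine, a carboxylic acid or a phenyl ring on this carbon would also leave the number in place. The three compounds also share the rest of the core, which leaves open what replacing the hydroxy group or the ((2-methylprop-1-en-1-yl)carbonyl)oxy group would do, and whether any such change would produce a step beyond the scatter.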